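Swapping the side chain of compound 3

A few compounds are considered here, and "the series" means these few. Any claim that something is new, unique, unknown or untested is made for them only; others in the source may bear on it.

Measured in a physicochemical assay for solubility, in phosphate buffer, with a stated time of 18 h, at pH 7.4; on this read-out lower numbers stand for lower solubility and higher numbers for higher solubility:
- compound 1 `COc1cc2ncnc(-n3nc(-c4ccccn4)nc3N)c2cc1N` gives 3000 nM
- compound 2 `COc1cc2c(-n3nc(-c4ccccn4)nc3N)ncnc2cc1OCc1ccccc1` gives 68000 nM
- compound 3 `CCN(CC)C(=O)COc1cc2c(-n3nc(-c4ccccn4)nc3N)ncnc2cc1OC` gives 42000 nM

The number for compound 3 sits within the usual scatter of the number for compound 2, and both stand well above the number for compound 1.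

Compound 4 `COc1cc2ncnc(-n3nc(-c4ccccn4)nc3N)c2cc1OCCCNC(=O)OC(C)C` has not been measured yet. It differs from compound 3 in one place, and the change is 2-((isopropoxycarbonyl)amino)ethyl in place of diethylcarbamoyl on a saturated chain carbon bound to an oxygen on an aromatic ring. In words, 2-((isopropoxycarbonyl)amino)ethyl stands in place of diethylcarbamoyl on a saturated chain carbon bound to an oxygen on an aromatic ring.

Among the compounds with values here, only one measured step bears on this, and only indirectly. That step is a 14-fold higher number from compound 1 to compound 3 (1.15 log units; beyond the scatter), a large one and beyond the scatter, and it put (diethylcarbamoyl)methoxy in place of amino on an aromatic carbon. It suggests that changes to this part of the molecule can matter. However, compound 3 and compound 4 both keep a chain on the oxygen, and no measured step swaps one such chain for another. A jump of that size is therefore not expected in this assay.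

What is expected instead is a 1.7-fold lower number from compound 3 to compound 4 (0.23 log units; within the scatter), an estimate that stays within the scatter.

For compound 4 the estimated value is 25000 nM, with an expected range from 8000 nM to 70000 nM.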

Compound 4, solubility: 18000 nM
For compound 4 the middle estimate is 1.4-fold (0.14 log units) above the measured one, and the stated range covers the measured number.
By their numbers in this assay, from the lowest: compound 1; then compound 4; then compounds 3 and 2 (each within the scatter of the next).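

In this assay, the choice of chain on this oxygen turns out to matter in its own right: with 2-((isopropoxycarbonyl)amino)ethyl in place of diethylcarbamoyl, there is a 2.3-fold lower number from compound 3 to compound 4 (0.37 log units; beyond the scatter), so even a swap of one chain for another can move the number past ordinary repeat-to-repeat noise. The step is modest, though, and much of the difference from the amino-bearing compound remains, with a 6.0-fold higher number from compound 1 to compound 4 (0.78 log units; beyond the scatter) for 3-((isopropoxycarbonyl)amino)propoxy in place of amino on an aromatic carbon. Counting atoms shows that the chain entering is larger and has a hydrogen-bond donor where the one leaving has none, yet no measurement here explains the drop in the number.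

The two chains differ in several features at once, so the compounds shown cannot tell whether the chain's length, its end group or the two together account for the step. A longer chain with the same isopropoxycarbonyl end, or a chain of the same length ending in a plain amine or a carboxylic acid, would help pull those features apart.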